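Swapping a Pyrrole for a Pyridine on the Shared Core

The compounds below may be only part of what the source reports. "The series", "measured", "known", "first", "only" and "open" are said of these compounds alone.

Compound 2 `CCOC(=O)C1=C(Nc2ccccc2)S/C(=C\c2ccc[nH]2)C1=O` gives 16.2% in a functional assay on K562 cells (Homo sapiens) for inhibition, read by MTT assay, with a stated time of 72 h, tested at 10 uM; on this read-out higher numbers stand for more inhibition at the one concentration tested (going by the name of the read-out) and lower numbers for less inhibition. That is the lowest of the two numbers measured, and its nearest neighbour is compound 1 `CCOC(=O)C1=C(Nc2ccccc2)S/C(=C\c2ccc(Br)c(O)c2)C1=O`, which in this assay gives 22%. Compound 3 `CCOC(=O)C1=C(Nc2ccccc2)S/C(=C\c2cccnc2)C1=O` differs from compound 2 by pyridin-3-yl in place of 1H-pyrrol-2-yl on a double-bonded chain carbon bound to a double-bonded ring carbon. Within the data shown here, the only step that touches this position is a number 5.8 percentage points lower from compound 1 to compound 2 (within the scatter), so a change at this place has so far left the read-out unmoved. For compound 3 a step of a number 2.8 percentage points higher from compound 2 to compound 3 (within the scatter) is expected, within the scatter. Compound 3 is therefore estimated at 19%, with a range from 5% to 35%.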

Compound 3, a percentage reported as inhibition, at one concentration (the size of the read-out at that concentration, not a potency): < 10%
Compound 3 gave a limit, no number; the forecaster's own chance of this, stated with the estimate: 0%; middle value at least 9 percentage points away from the limit.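

Compound 3 gives a limit, not a number: the limit of < 10% in this assay, at which 1 of the 3 values shown sits.

Even so, this place on a double-bonded chain carbon bound to a double-bonded ring carbon now shows that the read-out can respond to a change of group: pyridin-3-yl in place of 4-bromo-3-hydroxyphenyl gives a number at least 12 percentage points lower from compound 1 to compound 3 (beyond the scatter), the only step here that clears the scatter. The change from 1H-pyrrol-2-yl gives a number at least 6.2 percentage points lower from compound 2 to compound 3 (that floor lies within the scatter), so that swap alone remains unresolved.

On these data alone, how a carboxylic acid or an amine would read at this place stays open.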